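Widening the chain on the aromatic nitrogen: compound 3

The source may hold more compounds than are shown below. What is called first, only, known or untested is meant among the compounds shown, and "the series" means these compounds.

- compound 1 `CCn1cc(C(=O)C(=O)Nc2ccc(OC)nc2)c2ccccc21`: 219 nM
- compound 2 `COc1ccc(NC(=O)C(=O)c2cn(CC(C)C)c3ccccc23)cn1`: 317 nM

In a functional assay on FaDu cells (Homo sapiens) for cytotoxicity, read by MTT assay, with a stated time of 72 h (on this read-out lower numbers stand for higher toxicity in this test and higher numbers for lower toxicity in this test), compound 2 gives 317 nM. Within the data shown here, its only neighbour, compound 1, gives 219 nM, and the two lie within the scatter of each other, so no order between them can be claimed.

The next structure is compound 3 `COc1ccc(NC(=O)C(=O)c2cn(CC3CCCO3)c3ccccc23)cn1`. It has oxolan-2-yl in place of isopropyl on a saturated chain carbon bound to an aromatic nitrogen. Cut one bond further out, this reads isobutyl to (oxolan-2-yl)methyl.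

Among the measured compounds shown here, one measured step bears on this change, made at the same place: a 1.4-fold higher number from compound 1 to compound 2 (0.16 log units; within the scatter). That step is small, but it covers only open chains. For the measured compounds named here, the data hold no compound with a ring or a hydrogen-bond acceptor in this chain, so the evidence is thin and the range stays wide. No step beyond the scatter is expected in this assay, and no direction is favoured. The expected step is a 1.1-fold lower number from compound 2 to compound 3 (0.02 log units; within the scatter). For compound 3 the estimated value is 300 nM, with an expected range of 110 nM to 800 nM.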

Compound 3, concentration lethal to 50% of the cells: 31 nM
Estimate against measurement, compound 3: 9.7-fold (0.99 log units) above, and the stated range ends above it.
By their numbers in this assay, from the lowest: compound 3; then compounds 1 and 2 (each within the scatter of the next).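

In this assay, the chain on the aromatic nitrogen proves able to move the read-out well beyond the scatter, which the open chains of compound 1 and compound 2 did not show: oxolan-2-yl in place of isopropyl gives a 10-fold lower number from compound 2 to compound 3 (1.01 log units; beyond the scatter) and oxolan-2-yl in place of methyl gives a 7.1-fold lower number from compound 1 to compound 3 (0.85 log units; beyond the scatter) (the second step is the smaller by its printed label, but both point the same way). Among these three compounds, the lower number goes with the only chain that carries a five-membered non-aromatic ring and a hydrogen-bond acceptor, and neither compound 1 nor compound 2 goes against this, though a single compound with that chain is thin support for a pattern. Nothing at hand accounts for the step.

Still open, as far as these compounds go, is whether the ring or its oxygen goes with the lower number, since both enter together in compound 3; a cyclopentyl ring or an open 2-methoxyethyl chain at this place would separate the two. Also open, from the compounds shown here alone, is how the oxolan-2-yl result compares with a six-membered oxane ring or a longer chain carrying the same ring.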